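A few compounds are considered here, and "the series" means these few. Any claim that something is new, unique, unknown or untested is made for them only; others in the source may bear on it.

Three compounds have been measured in an ADME assay on HEL cells (Homo sapiens) for cytotoxicity, read by microscopy, with a stated time of 3 days; on this read-out higher numbers stand for lower toxicity in this test and lower numbers for higher toxicity in this test:

Compound 1 `CCOC(=O)C1(Cc2ccccc2)CN(c2ccccc2)Cc2nnn(Cc3cccc(F)c3)c21`: >= 100000 nM
Compound 2 `CCOC(=O)C1(Cc2ccccc2)CN(c2ccccc2)Cc2nnn(Cc3ccc(Cl)c(Cl)c3)c21`: > 100000 nM
Compound 3 `CCOC(=O)C1(Cc2ccc(F)cc2)CN(c2ccccc2)Cc2nnn(Cc3ccc(Cl)c(Cl)c3)c21`: > 100000 nM

Compound 3 stands at a limit of this assay, not at a number: its value of > 100000 nM only tells that no toxicity appeared up to the highest concentration tested. Compound 2 likewise sits at a limit, > 100000 nM. Compound 1 sits at a limit too, >= 100000 nM. All three values are therefore ceilings, as the limit of > 100000 nM in this assay, at which 2 of the 3 values shown sit, and the limit of >= 100000 nM in this assay, at which 1 of the 3 values shown sits, show, and none of them can be ranked against another.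

Compound 4 `CCOC(=O)C1(Cc2ccc(F)cc2)CN(c2ccccc2)Cc2nnn(Cc3cccc(F)c3)c21` is not yet measured. It differs from compound 3 in one place: 3-fluorophenyl in place of 3,4-dichlorophenyl on a saturated chain carbon bound to an aromatic nitrogen. Going by the values given here, this is the same exchange, run backwards, as the one from compound 1 to compound 2, where the step was a step that the two limits leave unreadable from compound 1 to compound 2. The other measured step, a step that the two limits leave unreadable from compound 2 to compound 3, touches a different position and was equally unreadable. Nothing in these three compounds gives a readable step for this exchange, and nothing points to a change in toxicity in either direction.

Compound 4 is therefore expected to remain at the limit, with an estimated step of a number no higher from compound 3 to compound 4 (the limit leaves the size open). For compound 4 the estimate in this assay is 100000 nM, with a range from 50000 nM to 300000 nM.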

Compound 4, minimum cytotoxic concentration: > 100000 nM
Compound 4 was reported as a limit; the forecaster's own chance of this, stated with the estimate: 85%; the middle value lies on the limit itself.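

In this assay compound 4 gives > 100000 nM, which is a limit of the assay and not a number. The steps to compound 4 from compound 3 and from compound 1 therefore cannot be read. The four compounds leave open at what concentration any of them would become toxic to these cells, and whether either exchange changes that concentration.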